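Bromine moved around the benzyl ring: expecting compound 4

The source may report more compounds than this note shows. Statements on the series, on what has been measured and on what is new or still open speak of the compounds shown alone.

Measured compounds in an ADME assay on MT4 cells (Homo sapiens) for cytotoxicity, read by MTT assay, with a stated time of 4 days; on this read-out lower numbers stand for higher toxicity in this test and higher numbers for lower toxicity in this test:
Compound 1 `CCOC(=O)c1cnc(N2CCN(Cc3ccccc3C#N)CC2)nc1Oc1c(C)cc(-c2ccc(C#N)cc2)cc1C` gives only a limit in this assay, > 125000 nM.
Compound 2 `CCOC(=O)c1cnc(N2CCN(Cc3ccccc3C(=O)OC)CC2)nc1Oc1c(C)cc(-c2ccc(C#N)cc2)cc1C` gives only a limit in this assay, > 125000 nM.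
Compound 3 `CCOC(=O)c1cnc(N2CCN(Cc3ccc(Br)cc3)CC2)nc1Oc1c(C)cc(-c2ccc(C#N)cc2)cc1C` gives only a limit in this assay, > 125000 nM.

Compound 3 therefore stands at the limit of the assay, where all three measured compounds sit (the limit of > 125000 nM in this assay, at which 3 of the 3 values shown sit). Compound 4 `CCOC(=O)c1cnc(N2CCN(Cc3cccc(Br)c3)CC2)nc1Oc1c(C)cc(-c2ccc(C#N)cc2)cc1C` differs from compound 3 by a single change: 3-bromophenyl in place of 4-bromophenyl on a saturated chain carbon bound to an amine nitrogen in a ring.

Three steps among the measured compounds bear on this change, each varying the group on the same saturated chain carbon. The step that the two limits leave unreadable from compound 1 to compound 2, the step that the two limits leave unreadable from compound 1 to compound 3 and the step that the two limits leave unreadable from compound 2 to compound 3 all stay hidden behind the limit, so their size cannot be read. For the measured compounds named here, no measured step shows any movement away from the limit in this assay. The change from compound 3 to compound 4 keeps the same atoms and the same bromophenyl group, joined differently, and the steps seen so far give no reason to expect a departure from the limit.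

Compound 4 is therefore expected to reach 125000 nM, in the range 60000 nM to 250000 nM, with the step of a number no higher from compound 3 to compound 4 (the limit leaves the size open) expected to be none beyond the scatter.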

Compound 4, half-maximal cytotoxic concentration: > 125000 nM
Compound 4 ended at the assay's limit (the forecaster's own chance of this, stated with the estimate: 85%); the middle value sits exactly at the limit.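

In this assay compound 4 gives only a limit, > 125000 nM, so its steps to compound 1, compound 2 and compound 3 cannot be read: the limit of > 125000 nM in this assay, at which 4 of the 4 values shown sit.

The compounds shown leave open whether any group on this saturated chain carbon would bring a readable value in this test.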